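The source may report more compounds than this note shows. Statements on the series, on what has been measured and on what is new or still open speak of the compounds shown alone.

Measured compounds:
- compound 1 `Cc1c(CC(=O)O)c(-c2ccccc2)nn1Cc1ccc(S(C)(=O)=O)cc1`: "not active" (no number reported) in a functional assay on CHO-K1 cells for antagonist activity at prostaglandin D2 receptor 2 (Homo sapiens), read by scintillation counting and GTPgammaS binding, with stated times of 1 h and 2 h; on this read-out higher numbers stand for weaker inhibition and lower numbers for stronger inhibition
- compound 2 `Cc1c(CC(=O)O)c(-c2ccccc2)nn1Cc1ccccc1S(=O)(=O)N1CCOCC1`: 89 nM in this assay

In this assay, among the compounds with values here, compound 2 gives 89 nM and is the only compound with a number; compound 1 is reported without one, as noted. Within the data shown here, no two measured compounds differ in a single place, so no measured step of any kind is available from this pair.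

Compound 3 `Cc1c(CC(=O)O)c(-c2ccccc2)nn1Cc1ccccc1S(=O)(=O)N(C)C` differs from compound 2 by dimethylamino in place of morpholin-4-yl on a sulfonyl sulfur — dimethylamino in place of morpholin-4-yl on a sulfonyl sulfur, the same difference cut one bond further out reading (morpholin-4-yl)sulfonyl to dimethylsulfamoyl. Among the measured compounds shown here, with no comparable measured step, the expectation rests on the change being confined to the group on the sulfonyl sulfur. The step is expected to be small, a 1.2-fold higher number from compound 2 to compound 3 (0.09 log units; within the scatter), within the usual scatter, in no firm direction. Compound 3 is therefore estimated at 110 nM. The expected range for compound 3 runs from 40 nM to 320 nM.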

Compound 3, half-maximal inhibitory concentration: 850 nM
Estimate against measurement, compound 3: 7.7-fold (0.89 log units) below; measured number above the stated range.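

The group on the sulfonyl sulfur is not a silent position in this assay: dimethylamino in place of morpholin-4-yl gives a 9.6-fold higher number from compound 2 to compound 3 (0.98 log units; beyond the scatter) and so moves the read-out toward weaker inhibition. Within the data shown here, this is the first measured sign that inhibition depends on what this sulfonyl sulfur carries, and here the six-membered non-aromatic ring outperforms the open, ring-free group. Nothing available on these compounds accounts for the size of this step.

The compounds shown do not separate the loss of the ring from the loss of its oxygen, since both leave together in this single change. Going by these compounds, how piperidin-1-yl, which keeps a ring without oxygen, or a longer chain such as diethylamino would read on this sulfonyl sulfur remains open.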